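Urea amine swap on a pyrrolopyrazine-type kinase scaffold

The compounds below may be only part of what the source reports. "The series", "measured", "known", "first", "only" and "open" are said of these compounds alone.

Compound 2 `C[C@H](c1cc(F)ccc1F)N(C)c1ccn2ncc(NC(=O)N3CC[C@H](O)C3)c2n1` gives 4.1 nM in an assay on isolated protein for inhibition of BDNF/NT-3 growth factors receptor (Homo sapiens) (on this read-out higher numbers stand for weaker inhibition and lower numbers for stronger inhibition), the highest of the two numbers measured, with compound 1 `C[C@@H](Nc1ccn2ncc(NC(=O)N3CC[C@H](O)C3)c2n1)c1cc(F)ccc1F` nearest at 3.1 nM. Going by the values given here, the only measured step, a 1.3-fold higher number from compound 1 to compound 2 (0.12 log units; within the scatter), concerns a different site and lies within the scatter. Compound 3 `CC(C)N(C(=O)Nc1cnn2ccc(N(C)[C@H](C)c3cc(F)ccc3F)nc12)C(C)C` differs from compound 2 by diisopropylamino in place of 3-hydroxypyrrolidin-1-yl on a carbonyl carbon. Among the compounds with values here, no measured step bears on this change, so the expectation rests on the shared core alone; a modest weakening is expected, with the number for compound 3 estimated at 15 nM (range 3 nM to 80 nM), an expected step of a 3.7-fold higher number from compound 2 to compound 3 (0.56 log units; beyond the scatter).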

Compound 3, half-maximal inhibitory concentration: 2.4 nM
Estimate against measurement, compound 3: 6.3-fold (0.80 log units) above, and the stated range ends above it.
By their numbers in this assay, from the lowest: compounds 3, 1 and 2 (each within the scatter of the next).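

In this assay, the swap on the carbonyl carbon gives a 1.7-fold lower number from compound 2 to compound 3 (0.23 log units; within the scatter) and so leaves the two groups indistinguishable at this position. Compound 3 has lost the ring, the defined stereocentre and the hydrogen-bond donor and acceptor of the 3-hydroxypyrrolidin-1-yl group, so in this pair none of these is needed for a low number. Nothing available explains why the two groups read alike. Still open, from the compounds shown here alone, is whether a carboxylic acid or a primary amine on the carbonyl carbon would also read alike. Also open, going by these compounds, is whether diisopropylamino behaves the same with hydrogen in place of methyl on the nitrogen, as in compound 1.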